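Methylating the Hydroxy Group of Compound 1

The compounds below may be only part of what the source reports. "The series", "measured", "known", "first", "only" and "open" are said of these compounds alone.

Compound 1 (`O=C(Nc1cccc(-n2cc(-c3ccncc3)c(-c3ccc(Cl)c(O)c3)n2)c1)Nc1cccc(C(F)(F)F)c1`) gives only a limit in a functional assay on MOLT-4 cells (Homo sapiens) for inhibition, read by sulforhodamine B assay, with a stated time of 48 h; on this read-out lower numbers stand for higher toxicity in this test and higher numbers for lower toxicity in this test (> 32500 nM). Compound 2 (`COc1cc(-c2nn(-c3cccc(NC(=O)c4cccc(C(F)(F)F)c4)c3)cc2-c2ccncc2)ccc1Cl`) also gives only a limit in this assay (> 50000 nM). Compound 3 (`COc1cc(-c2nn(-c3cccc(NC(=O)Nc4cccc(C(F)(F)F)c4)c3)cc2-c2ccncc2)ccc1Cl`) differs from compound 1 by methyl in place of hydrogen on an oxygen on an aromatic ring, hydroxy to methoxy (methyl in place of hydrogen on an oxygen on an aromatic ring). For the measured compounds named here, no measured step shows what this change does in this assay. The expected size is a step that the limit leaves unreadable from compound 1 to compound 3, which would stay within the usual scatter, with no direction favoured. For compound 3 the estimate is 45000 nM (15000 nM to 100000 nM), and the assay may again report only a limit.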

Compound 3, concentration lethal to 50% of the cells: > 50000 nM
Compound 3: only a limit was reported; the forecaster's own chance of this, stated with the estimate: 70%; middle value at least 1.1-fold (0.04 log units) from the limit.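

Compound 3 also gives only a limit in this assay (> 50000 nM), so neither step, from compound 1 or from compound 2 to compound 3, can be read. The compounds shown leave open what this assay would show for hydroxy to methoxy.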